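This account rests on a few compounds, and the source may have more. Where it says the series, first, only, none or still open, it means among the compounds named here.

Measured in a functional assay on MONO-MAC-6 cells (Homo sapiens) for cytotoxicity, read by MTT assay, with a stated time of 24 h; on this read-out lower numbers stand for stronger inhibition and higher numbers for weaker inhibition:
- compound 1 `O=C(Nc1ccc(C(F)(F)F)cc1)c1cc(Cl)ccc1O` gives 2200 nM
- compound 2 `O=Cc1ccc(O)c(C(=O)Nc2ccc(C(F)(F)F)cc2)c1` gives 21500 nM
- compound 3 `O=C(Nc1ccc(Cl)c(Cl)c1)c1cc(Br)ccc1O` gives 1400 nM

Among these three, compound 1 and compound 3 lie within the usual scatter of each other, so no order can be drawn between them. Compound 2 has the highest number of the three, well clear of compound 1.

The next compound to be tested is compound 4 `CC(=O)c1ccc(NC(=O)c2cc(Cl)ccc2O)cc1`, which has acetyl in place of trifluoromethyl on an aromatic carbon, para to a large group. The counted difference from compound 1 is acetyl in place of trifluoromethyl on an aromatic carbon.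

Among the measured compounds shown here, only one measured step bears on this change, and only loosely. Compound 2 brings in formyl in place of chloro, giving a 9.8-fold higher number from compound 1 to compound 2 (0.99 log units; beyond the scatter), a modest step beyond the scatter. Formyl and acetyl both contain a carbonyl, but they replace different groups, so this single step is a weak guide. For the measured compounds named here, no measured compound shows the loss of trifluoromethyl alone. A step in the same direction is therefore expected in this assay, towards weaker inhibition, though probably a smaller one.

The estimated step is a 3.2-fold higher number from compound 1 to compound 4 (0.50 log units; beyond the scatter), with considerable uncertainty. For compound 4 the expected value is 7000 nM, with an estimated range from 2200 nM to 22000 nM.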

Compound 4, half-maximal inhibitory concentration: 16100 nM
Estimate against measurement, compound 4: 2.3-fold (0.36 log units) below, and the stated range covers the measured number.
By their numbers in this assay, from the lowest: compounds 3 and 1 (each within the scatter of the next); then compounds 4 and 2 (each within the scatter of the next).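

Compound 2 changed compound 1 at the chloro, so compound 4 gives the first view of the carbon that holds trifluoromethyl, an aromatic carbon para to a large group. In this assay, acetyl in place of trifluoromethyl gives a 7.3-fold higher number from compound 1 to compound 4 (0.86 log units; beyond the scatter), so this position is not indifferent to the group it carries: this one replacement moves the number towards weaker inhibition, by a step beyond the usual scatter. The swap removes a group of 4 heavy atoms with no hydrogen-bond acceptor and brings in one of 3 heavy atoms with 1 hydrogen-bond acceptor, but no measurement here explains why the number rises.

On these data alone, it remains open whether the step reflects the loss of trifluoromethyl, the arrival of acetyl or both, and a methyl, a nitrile or an amine on this same carbon could help to separate those readings. As far as these compounds go, it is also open whether the same replacement would give a similar step if the chloro of compound 1 were changed as well.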